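Iodo in Place of Chloro on the Shared Core

The compounds below may be only part of what the source reports. "The series", "measured", "known", "first", "only" and "open" are said of these compounds alone.

Of the compounds shown here, three built on one core have been measured. Compound 1 `O=c1oc2ccc(F)cc2c(=O)n1-c1ccc(I)cc1F`, compound 2 `O=c1oc2ccc(F)cc2c(=O)n1-c1ccc(Cl)cc1F` and compound 3 `O=c1oc2ccc(Cl)cc2c(=O)n1-c1ccc(I)cc1F` were tested in an ADME assay on RAW264.7 cells (Mus musculus) for cytotoxicity, read by MTT assay, with a stated time of 24 h; a higher number here means that more compound is tolerated, a lower number that less compound is tolerated. In this assay compound 1 gives 6000 nM, compound 2 gives 7900 nM and compound 3 gives 6900 nM.

Compound 1 arises from compound 2 by the change (iodo in place of chloro on an aromatic carbon), and this step gave a 1.3-fold lower number from compound 2 to compound 1 (0.12 log units; within the scatter). Compound 4 `O=c1oc2ccc(I)cc2c(=O)n1-c1ccc(I)cc1F` arises from compound 3 by iodo in place of chloro on an aromatic carbon. The two changes are the same kind of change, not the same: the first sits on a ring meta to a fluoro group and para to a large group, the second on a ring that is part of a fused system of two rings, meta and para to the fused ring. How the core of compound 2 differs from the core of compound 3 is not broken down here.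

Because the earlier step of a 1.3-fold lower number from compound 2 to compound 1 (0.12 log units; within the scatter) stayed within the scatter, compound 4 is expected to show a step of a 1.1-fold lower number from compound 3 to compound 4 (0.03 log units; within the scatter) in this assay. The estimate for compound 4 is 6500 nM, between 3500 nM and 12000 nM.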

Compound 4, half-maximal cytotoxic concentration: 7600 nM
Compound 4: the middle estimate sits 1.2-fold (0.07 log units) below what was measured; low and high end bracket the measured number.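

In this assay, iodo in place of chloro on an aromatic carbon gave a 1.1-fold higher number from compound 3 to compound 4 (0.04 log units; within the scatter), and replacing fluoro with iodo gave a 1.3-fold higher number from compound 1 to compound 4 (0.10 log units; within the scatter). Set beside the earlier step, the same kind of change on a different ring of the shared core does not read differently: the same change on two cores in this assay, a 1.3-fold lower number (0.12 log units; within the scatter) from compound 2 to compound 1 and a 1.1-fold higher number (0.04 log units; within the scatter) from compound 3 to compound 4, 1.5-fold (0.16 log units) apart, within the scatter of two such steps. This shows that, for these two pairs, iodo in place of chloro stayed within the scatter wherever it was placed, but neither step gives the change a reliable direction, and two pairs cannot show that the result would carry to other cores in the series.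

The compounds shown carry only fluoro, chloro and iodo at the varied places, so it remains open whether an amine, a carboxylic acid or a longer chain at those places would shift the number in this assay. Also open, on these data alone, is whether the 2-fluoro group on the other ring has any bearing on these results, as it is the same in all four compounds.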